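This account rests on a few compounds, and the source may have more. Where it says the series, first, only, none or still open, it means among the compounds named here.

In a functional assay on HeLa cells (Homo sapiens) for inhibition, read by MTT assay, with a stated time of 72 h (on this read-out higher numbers stand for weaker inhibition and lower numbers for stronger inhibition), compound 1 `COc1ccc(/C=C/C(=O)c2c(OC)cc(O)c(CC=C(C)C)c2O)cc1` gives only a limit, > 50000 nM. For the measured compounds named here, compound 2 `COc1ccccc1/C=C/C(=O)c1c(OC)cc(O)c(CC=C(C)C)c1O` gives 19700 nM, the only actual number so far. Compound 3 `COc1cc(O)c(CC=C(C)C)c(O)c1C(=O)/C=C/c1ccc(Cl)cc1` differs from compound 2 with 4-chlorophenyl in place of 2-methoxyphenyl on a double-bonded chain carbon bound to a double-bonded chain carbon. Going by the values given here, the one measured step bearing on this, an at least 2.5-fold lower number from compound 1 to compound 2 (0.40 log units; beyond the scatter), replaced 4-methoxyphenyl with 2-methoxyphenyl, so a modest rise in this assay, towards weaker inhibition, is expected with 4-chlorophenyl. The estimated step is a 1.4-fold higher number from compound 2 to compound 3 (0.15 log units; within the scatter). Compound 3 is expected at 28000 nM, with an estimated range from 11000 nM to 60000 nM.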

Compound 3, half-maximal inhibitory concentration: 16500 nM
Estimate against measurement, compound 3: 1.7-fold (0.23 log units) above; the measured number falls inside the stated range.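

In this assay the change to 4-chlorophenyl on a double-bonded chain carbon bound to a double-bonded chain carbon gives a 1.2-fold lower number from compound 2 to compound 3 (0.08 log units; within the scatter) and leaves the two compounds level. Chloro in place of methoxy on an aromatic carbon gives an at least 3.0-fold lower number from compound 1 to compound 3 (0.48 log units; beyond the scatter) and so sets 4-chlorophenyl, like 2-methoxyphenyl, apart from 4-methoxyphenyl. Going by these compounds, the full size of that step stays unknown, since compound 1 gives only a limit: the limit of > 50000 nM in this assay, at which 1 of the 3 values shown sits. On these data alone, whether an amine or a carboxylic acid on this aromatic ring would bring the number lower remains open.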